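The source may report more compounds than this note shows. Statements on the series, on what has been measured and on what is new or still open speak of the compounds shown alone.

Within the data shown here, compound 2 `COc1ccc(NC(=O)OC[C@H](C2CC2)n2cc(Cl)nc(Nc3cc(C)c(OC)nc3C)c2=O)c(C)n1` gives 9.2 nM in an assay on frontal cortex for displacement of a labelled ligand from corticotropin-releasing factor receptor 1 (Rattus norvegicus), with a stated time of 2 h (on this read-out higher numbers stand for weaker inhibition and lower numbers for stronger inhibition), the higher of the two numbers measured so far; compound 1 `COc1nc(C)c(Nc2nc(Cl)cn([C@H](COC(=O)Nc3ccc(Cl)cc3Cl)C3CC3)c2=O)cc1C` gives 1.7 nM in this assay. Among the measured compounds shown here, the single measured step, a 5.4-fold higher number from compound 1 to compound 2 (0.73 log units; beyond the scatter), exchanged the aromatic ring on the amide-type nitrogen. Compound 3 `COc1nc(C)c(Nc2nc(Cl)cn([C@H](COc3ccc(C(F)(F)F)cn3)C3CC3)c2=O)cc1C` differs from compound 2 by 5-(trifluoromethyl)pyridin-2-yl in place of (6-methoxy-2-methylpyridin-3-yl)carbamoyl on an oxygen on a saturated carbon. For the measured compounds named here, that swap removes the carbamoyl group entirely and sets an aromatic ring directly on the oxygen, a change of a kind that no measured step covers; the step from compound 1 to compound 2 only shows that swapping the ring on the nitrogen shifted the number beyond the scatter but not greatly. Going by the values given here, with no direct precedent, compound 3 is expected to lie near compound 2. The estimated step of a 1.3-fold lower number from compound 2 to compound 3 (0.12 log units; within the scatter) is therefore expected to be small, with a wide range. Compound 3 is estimated at 7 nM, between 1.5 nM and 35 nM.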

Compound 3, half-maximal inhibitory concentration: 1.6 nM
Beside the measured number, compound 3's estimate is 4.4-fold (0.64 log units) above it, within the range that was stated.
By their numbers in this assay, from the lowest: compounds 3 and 1 (each within the scatter of the next); then compound 2.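

The carbamoyl group is not required at this oxygen for a low number in this assay: setting an aromatic ring directly on the oxygen, which also removes the amide hydrogen, gives a 5.8-fold lower number from compound 2 to compound 3 (0.76 log units; beyond the scatter), and against the dichlorophenyl carbamate it gives a 1.1-fold lower number from compound 1 to compound 3 (0.03 log units; within the scatter). The earlier step changed only the ring on the carbamoyl nitrogen, whereas this change replaces the whole carbamoyl unit and still gives a number in the same range as the better of the two carbamates. Nothing measured here bears on the reason for this result.

Among these compounds, compound 3 is the only example with a ring directly on this oxygen, so it remains open how a plain phenyl ring or a simple methyl group would compare there. The role of the trifluoromethyl group is also open, since no compound shown has a chlorine or a nitrile in its place.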